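The source may hold more compounds than are shown below. What is called first, only, known or untested is meant among the compounds shown, and "the series" means these compounds.

Compound 1, `C[C@@H](NC(=O)Nc1ccccc1C(F)(F)F)c1ccccc1`, gives 95% in an ADME assay on the whole organism with Oryza sativa as the target, tested at 1 uM; a higher number here means a weaker effect of the compound at the concentration tested, a lower number a stronger effect. Compound 2, `C[C@H](NC(=O)Nc1ccccc1C(F)(F)F)c1ccccc1`, gives 98%. Compound 3, `C[C@H](NC(=O)Nc1ccc(F)cc1)c1ccccc1`, gives 97%.

Compound 2 has the highest of the three numbers, but its distance to compound 3 and to compound 1 lies within the scatter. Within the data shown here, the only measured step, a number 3 percentage points higher from compound 1 to compound 2 (within the scatter), rests on the fact that compounds 1 and 2 differ only in the configuration as drawn and so concerns configuration alone; it offers no guide to exchanging a group. Compound 4, `C[C@H](NC(=O)Nc1ccccc1I)c1ccccc1`, arises from compound 2 by iodo in place of trifluoromethyl on an aromatic carbon. Compound 3, which carries a different group on the same kind of ring, gives a number close to compound 2, so no step beyond the scatter is expected. Compound 4 is therefore expected to give about 96%, between 88% and 100%. The expected step is a number 2 percentage points lower from compound 2 to compound 4 (within the scatter).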

Compound 4, a percentage reported as activity, at one concentration (the size of the read-out at that concentration, not a potency): 100%
The estimate for compound 4 lay 4 percentage points below the measured number; the range from low to high includes it.
By their numbers in this assay, from the lowest: compounds 1, 3, 2 and 4 (each within the scatter of the next).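

Iodo in place of trifluoromethyl on an aromatic carbon, ortho to a large group, gives a number 2 percentage points higher from compound 2 to compound 4 (within the scatter) in this assay and is the first exchange of a group with a step of its own here. At this place, a single iodine atom and a trifluoromethyl group of 4 heavy atoms cannot be told apart by this read-out. Nothing measured here explains this result.

As far as these compounds go, whether an amine or a carboxylic acid at this place would give a step beyond the scatter remains open. Also open, from the compounds shown here alone, is whether the drawn configuration matters for the iodo compound.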